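Adding One Carbon to the Chain of Compound 3

The source may hold more compounds than are shown below. What is called first, only, known or untested is meant among the compounds shown, and "the series" means these compounds.

In a functional assay on K562 cells (Homo sapiens) for antiproliferative activity, read by MTT assay, with a stated time of 48 h (a higher number here means a weaker inhibitor, a lower number a stronger inhibitor), compound 1 (`Cn1c(N)c(-c2nc3ccccc3[nH]2)c2nc(C#N)c(C#N)nc21`) gives > 50000 nM, which is a limit and not a number. Compound 2 (`N#Cc1nc2c(-c3nc4ccccc4[nH]3)c(N)n(CCN3CCCC3)c2nc1C#N`) gives 6480 nM. Among the measured compounds shown here, compound 3 (`CCN(CC)CCCn1c(N)c(-c2nc3ccccc3[nH]2)c2nc(C#N)c(C#N)nc21`) gives 1800 nM, the lower of the two actual numbers so far.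

Compound 4 (`CCN(CC)CCCCn1c(N)c(-c2nc3ccccc3[nH]2)c2nc(C#N)c(C#N)nc21`) is still unmeasured. It replaces the 3-(diethylamino)propyl group of compound 3 with 4-(diethylamino)butyl ((diethylamino)methyl in place of diethylamino on a saturated chain carbon, three bonds along the chain from an aromatic nitrogen).

For the measured compounds named here, three measured steps bear on this. Two show what attaching an amine chain did: an at least 7.7-fold lower number from compound 1 to compound 2 (0.88 log units; beyond the scatter), and an at least 27-fold lower number from compound 1 to compound 3 (1.44 log units; beyond the scatter). Going by the values given here, the closest guide is a 3.6-fold lower number from compound 2 to compound 3 (0.56 log units; beyond the scatter), but that step swaps the amine as well as lengthening the chain, so no measured step isolates chain length. Since the change to compound 4 keeps the amine and the modest size of that closest step is an upper guide, a step within the scatter is expected in this assay, with no firm direction. The estimated step is a 1.2-fold lower number from compound 3 to compound 4 (0.08 log units; within the scatter). For compound 4, the expected value is 1500 nM, with an estimated range of 500 nM to 5000 nM.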

Compound 4, half-maximal inhibitory concentration: 1440 nM
Compound 4: middle estimate off by 1.0-fold (0.02 log units), on the high side, within the range that was stated.
By their numbers in this assay, from the lowest: compounds 4 and 3 (each within the scatter of the next); then compound 2. At a limit, above all of these: compound 1.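

In this assay, among the compounds shown here, the change to 4-(diethylamino)butyl keeps the diethylamino group and alters only the chain length, which no earlier step isolated, and it gives a 1.3-fold lower number from compound 3 to compound 4 (0.10 log units; within the scatter). Set against the shorter chain ending in pyrrolidin-1-yl, where the amine differs as well, the result is a 4.5-fold lower number from compound 2 to compound 4 (0.65 log units; beyond the scatter). Measured against a limit and not a number, the step from the methyl group to the new chain reads an at least 34-fold lower number from compound 1 to compound 4 (1.54 log units; beyond the scatter): the limit of > 50000 nM in this assay, at which 1 of the 4 values shown sits.

The compounds shown do not separate how much of the gap to pyrrolidin-1-yl belongs to the amine and how much to the chain. Also open, going by these compounds, is what a pentyl chain ending in diethylamino, or a butyl chain ending in morpholine or a primary amine, would give in this assay.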